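Bulky Group on the Ring Nitrogen: Predicting Compound 4

A few compounds are considered here, and "the series" means these few. Any claim that something is new, unique, unknown or untested is made for them only; others in the source may bear on it.

Measured compounds in an assay on isolated protein for inhibition of STE20-like serine/threonine-protein kinase (Homo sapiens), read by thermal shift assay, tested at 10 uM; a lower number here means that the compound stabilises the target less, a higher number that the compound stabilises the target more against heat:
- compound 1 `Cc1ccccc1NC(=O)Nc1cc(C(C)(C)C)nn1-c1ccccc1`: 7.1 degrees C
- compound 2 `CC(C)(C)c1cc(NC(=O)Nc2cc(C(F)(F)F)cc(C(F)(F)F)c2)n(-c2ccccc2)n1`: 0 degrees C
- compound 3 `Cn1nc(C(C)(C)C)cc1NC(=O)Nc1cc(C(F)(F)F)cc(C(F)(F)F)c1`: 2.4 degrees C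

Three ureas built on a shared core have been tested. Compound 1 gives the largest melting-temperature shift of the set, 7.1 degrees C. Compound 2 gives no stabilisation at all, 0 degrees C. Compound 3 stands second highest of the three, with 2.4 degrees C; its nearest neighbour is compound 2, and the gap to compound 1 is clearly beyond the scatter.

Compound 4 `CC(C)(C)c1cc(NC(=O)Nc2cc(C(F)(F)F)cc(C(F)(F)F)c2)n(C(C)(C)C)n1` differs from compound 3 in one place: tert-butyl in place of methyl on an aromatic nitrogen. For the measured compounds named here, the only measured step that bears on the group on the aromatic nitrogen is the one from compound 2 to compound 3, methyl in place of phenyl, which gave a number 2.4 degrees C higher from compound 2 to compound 3 (beyond the scatter). Going by the values given here, that step shows the group on this nitrogen matters, but no measured pair shows what a tert-butyl does there. A tert-butyl is closer in size to phenyl than to methyl, so some loss relative to compound 3 seems plausible, though a change within the scatter cannot be excluded.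

The estimate for compound 4 is 1.5 degrees C, with a range from 0 degrees C to 3.5 degrees C, meaning an expected step of a number 0.90 degrees C lower from compound 3 to compound 4 (within the scatter).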

Compound 4, shift of the target's melting temperature: -0.2 degrees C
Compound 4: the middle estimate sits 1.7 degrees C above what was measured, outside the stated range (below it).
By their numbers in this assay, from the lowest: compounds 4 and 2 (each within the scatter of the next); then compound 3; then compound 1.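

In this assay, a third group on this aromatic nitrogen shows that the outcome does not simply follow from having a carbon group there: tert-butyl in place of methyl gives a number 2.6 degrees C lower from compound 3 to compound 4 (beyond the scatter) and removes what methyl had provided. Tert-butyl in place of phenyl gives a number 0.20 degrees C lower from compound 2 to compound 4 (within the scatter) and so leaves the read-out unchanged, even though tert-butyl has no ring and phenyl does. Among these three compounds, which differ only at this nitrogen, methyl alone stands apart, with compound 3 at 2.4 degrees C in this assay, and nothing shown here explains why.

The compounds shown leave open where between methyl and tert-butyl the stabilisation is lost, which an ethyl, an isopropyl or a cyclopropyl on the same nitrogen would help to settle, and whether a plain hydrogen there would do better than methyl. They also leave open whether the same order of groups would hold with the other urea partner of compound 1, which reaches 7.1 degrees C with phenyl on this nitrogen.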